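The source may report more compounds than this note shows. Statements on the series, on what has been measured and on what is new or still open speak of the compounds shown alone.

Measured in a functional assay on AGS cells (Homo sapiens) for cytotoxicity, read by MTT assay, with a stated time of 48 h; on this read-out higher numbers stand for weaker inhibition and lower numbers for stronger inhibition:
Compound 1 `Cc1nc2c3ccccc3ccc2c2nc3c(ccc4ccccc43)c(-c3cccc([N+](=O)[O-])c3)c12` gives 25500 nM.
Compound 2 `COc1ccc(-c2c3ccc4ccccc4c3nc3c2c(C)nc2c4ccccc4ccc32)cc1` gives 66400 nM.
Compound 3 `Cc1ccc(-c2c3ccc4ccccc4c3nc3c2c(C)nc2c4ccccc4ccc32)cc1` gives > 80000 nM, which is a limit of the assay and not a number.

Compound 3 thus stands at the limit of > 80000 nM in this assay, at which 1 of the 3 values shown sits, the weakest reading shown. The step from it shares the 4-methylphenyl partner: an at least 3.1-fold higher number from compound 1 to compound 3 (0.49 log units; beyond the scatter), while an at least 1.2-fold higher number from compound 2 to compound 3 (0.08 log units; that floor lies within the scatter), a change of the same small kind. Compound 4 `Cc1nc2c3ccccc3ccc2c2nc3c(ccc4ccccc43)c(-c3ccccc3)c12` differs from compound 3 by hydrogen in place of methyl on an aromatic carbon. Among the compounds with values here, no measured step removes a methyl; the nearest, an at least 1.2-fold higher number from compound 2 to compound 3 (0.08 log units; that floor lies within the scatter), stayed within scatter, and a 2.6-fold higher number from compound 1 to compound 2 (0.42 log units; beyond the scatter) was modest. In this assay no step beyond the scatter is therefore expected: a number no higher from compound 3 to compound 4 (the limit leaves the size open). Compound 4 is estimated at 80000 nM, between 40000 nM and 160000 nM, most likely reported again as a limit.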

Compound 4, half-maximal inhibitory concentration: > 80000 nM
Compound 4: only a limit was reported; the forecaster's own chance of this, stated with the estimate: 60%; the middle value sits exactly at the limit.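

Compound 4, with phenyl in place of 4-methylphenyl, gives > 80000 nM in this assay, a limit of the assay and not a number. Compound 3 and compound 4 both sit at that limit, so the step between them cannot be read: the limit of > 80000 nM in this assay, at which 2 of the 4 values shown sit.

Plain phenyl still shows an at least 3.1-fold higher number from compound 1 to compound 4 (0.49 log units; beyond the scatter), while an at least 1.2-fold higher number from compound 2 to compound 4 (0.08 log units; that floor lies within the scatter), so of the groups shown only 3-nitrophenyl gives a number clearly lower than plain phenyl. From the compounds shown here alone, what an amine or a carboxylic acid would give in place of the methyl stays open.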